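The source may report more compounds than this note shows. Statements on the series, on what has been measured and on what is new or still open speak of the compounds shown alone.

Measured in a functional assay on HeLa cells (Homo sapiens) for cytotoxicity, read by MTT assay, with a stated time of 48 h; on this read-out lower numbers stand for stronger inhibition and higher numbers for weaker inhibition:

- compound 1 `C=C1CCC[C@]2(C)CCC(C=O)=CC[C@@]12C`: 191000 nM
- compound 2 `CC1(C)CCCC2=CC=C(C=O)CC[C@]21C`: 163000 nM

Going by the values given here, compound 1 stands level with compound 2, the only other measured compound, as the two values lie within the scatter of each other. Compound 3 `C#CC1=CC[C@@]2(C)C(=C)CCC[C@]2(C)CC1` has not yet been measured. It carries ethynyl in place of formyl on a double-bonded ring carbon of the core of compound 1 (ethynyl in place of formyl on a double-bonded ring carbon). Among the compounds with values here, no measured pair shows this change, so its size cannot be read directly from the data. Taking compound 1 at 191000 nM as the starting point, no step beyond the scatter is expected in this assay, and no direction is favoured with any confidence. The estimated 1.3-fold lower number from compound 1 to compound 3 (0.10 log units; within the scatter) is therefore small. For compound 3 the estimated value is 150000 nM, with an expected range from 60000 nM to 400000 nM in this read-out.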

Compound 3, half-maximal inhibitory concentration: 158000 nM
Compound 3: the middle estimate sits 1.1-fold (0.02 log units) below what was measured, and the stated range covers the measured number.
By their numbers in this assay, from the lowest: compounds 3, 2 and 1 (each within the scatter of the next).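

In this assay, ethynyl in place of formyl on a double-bonded ring carbon of the seven-membered non-aromatic ring gives a 1.2-fold lower number from compound 1 to compound 3 (0.08 log units; within the scatter), the first step read at this position. Formyl's one hydrogen-bond acceptor and its oxygen are both lost in this change, yet compound 3 stands level with compound 1, so formyl is not needed at this position for the weak cytotoxicity seen in this pair. No measurement on hand accounts for this level result.

On these data alone, whether a carboxylic acid or an amine at this position would move the number beyond the scatter remains open. Also open, as far as these compounds go, is whether ethynyl in place of formyl would give a similar result on the core of compound 2.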